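Swapping Chloro for Amino on a Ring-Alkyne Core

The source may hold more compounds than are shown below. What is called first, only, known or untested is meant among the compounds shown, and "the series" means these compounds.

Of the compounds shown here, two have been measured in an assay on brain for displacement of a labelled ligand from metabotropic glutamate receptor 5 (Rattus norvegicus); on this read-out lower numbers stand for stronger inhibition and higher numbers for weaker inhibition. Compound 1, `COc1cccc(C#Cc2csc(Cl)n2)c1`, gives 8.1 nM, the higher of the two numbers. Compound 2, `N#Cc1cc(F)cc(C#Cc2csc(N)n2)c1`, gives 0.25 nM, and the gap between the two lies beyond the usual scatter. Compound 2 differs from compound 1 at more than one place, so its number cannot be tied to any single change.

Compound 3, `COc1cccc(C#Cc2csc(N)n2)c1`, has not yet been measured. It carries the change (amino in place of chloro on an aromatic carbon), that is, amino in place of chloro on an aromatic carbon, on the ring that also bears the alkyne. Compound 2 shares this amino group and shows a much lower number than compound 1, which makes a move toward lower numbers the more likely outcome. The estimated step of a 4.1-fold lower number from compound 1 to compound 3 (0.61 log units; beyond the scatter) is expected to exceed the scatter. For compound 3 the expected value is 2 nM, in a range from 0.5 nM to 8 nM.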

Compound 3, inhibition constant: 18.6 nM
Compound 3: middle estimate off by 9.3-fold (0.97 log units), on the low side; the measured number lies above the stated range.
By their numbers in this assay, from the lowest: compound 2; then compound 1; then compound 3.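

In this assay, amino in place of chloro, on the aromatic carbon next to the ring nitrogen and next to the ring sulfur, gives a 2.3-fold higher number from compound 1 to compound 3 (0.36 log units; beyond the scatter), a modest step toward weaker inhibition. On the core of compound 1, then, this change does not lower the number, so the amino group that compound 2 also carries cannot by itself account for the low number of compound 2. Nothing measured here gives a reason for this rise.

Still open, from the compounds shown here alone, is how a methylamino group, a hydroxyl group or a plain methyl group would fare at this same position. Also open, going by these compounds, is what the change from chloro to amino does on the core of compound 2, since this single step speaks only for the core of compound 1.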